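Swapping a Methoxymethyl for a Hydroxy Group

The source may hold more compounds than are shown below. What is called first, only, known or untested is meant among the compounds shown, and "the series" means these compounds.

Three compounds share a core in which an aniline-type amine bridges a fused two-ring system carrying a pyridine. Compound 1 `c1ccc(Nc2c(-c3ccccn3)nc3ccccn23)cc1` is the plainest of them. Compound 2 `COc1ccnc(-c2nc3ccccn3c2Nc2ccc(F)cc2)c1` carries a fluorine on the aniline and a methoxy on the pyridine. Compound 3 `COCc1ccn2c(Nc3cccc(F)c3)c(-c3ccccn3)nc2c1` carries a fluorine on the aniline and a methoxymethyl on the fused system.

In an ADME assay on THP-1 cells (Homo sapiens) for cytotoxicity (a higher number here means that more compound is tolerated, a lower number that less compound is tolerated), compound 1 gives 6690 nM. In this assay compound 2 gives 4220 nM. In this assay compound 3 gives 7370 nM. The three numbers lie within the usual scatter of one another, so compound 3 stands alongside the other two rather than apart from them; nothing separates the three substitution patterns in how well the cells tolerate them.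

Compound 4 `Oc1ccn2c(Nc3cccc(F)c3)c(-c3ccccn3)nc2c1` keeps the fluorine and the pyridine but differs at one site: hydroxy in place of methoxymethyl on an aromatic carbon. Within the data shown here, no pair of compounds measured so far shows a change of this kind. Since none of the three changes seen so far moved the readout in this assay beyond the scatter, compound 4 is expected to sit where compound 3 sits, and the step of a 1.0-fold higher number from compound 3 to compound 4 (0.01 log units; within the scatter) is estimated to be no larger than the scatter. Compound 4 is therefore estimated at 7500 nM, with a range from 3500 nM to 16000 nM.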

Compound 4, half-maximal cytotoxic concentration: 43300 nM
Compound 4: middle estimate off by 5.8-fold (0.76 log units), on the low side, outside the stated range (above it).
By their numbers in this assay, from the lowest: compounds 2, 1 and 3 (each within the scatter of the next); then compound 4.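

In this assay, hydroxy in place of methoxymethyl on this aromatic carbon gives a 5.9-fold higher number from compound 3 to compound 4 (0.77 log units; beyond the scatter), so more of compound 4 is tolerated by the cells. Among these compounds, this is the first step in the set that lies beyond the scatter, and it shows that the group at this position, opposite the ring nitrogen, can change the read-out, even though the three different substitution patterns seen earlier could not be told apart. The change does more than one thing at once, replacing a chain of 3 heavy atoms with 1 heavy atom and adding 1 hydrogen-bond donor, and no measurement shown here says which of these differences matters, if either does.

From the compounds shown here alone, it remains open whether the hydroxy group itself is needed or whether losing the methoxymethyl chain is enough, and a plain methyl, an amine or a hydroxymethyl at the same carbon would help to separate those two readings. Going by these compounds, it also remains open whether the same swap would give a step of similar size with the fluorine elsewhere on the aniline ring, or with no fluorine at all.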